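The source may hold more compounds than are shown below. What is called first, only, known or untested is meant among the compounds shown, and "the series" means these compounds.

Working notes on the series, where the shared core stays fixed and one side chain varies. In a physicochemical assay for solubility (a lower number here means a less soluble compound, a higher number a more soluble compound), compound 1 `CSc1sc(C(=N)N)cc1S(=O)(=O)c1cccc(-c2c(C)cccc2NC(=O)CCCCC(=O)O)c1` gives 40000 nM, and compound 2 `CSc1sc(C(=N)N)cc1S(=O)(=O)c1cccc(-c2c(C)cccc2NC(=O)CS(C)(=O)=O)c1` gives 43000 nM. Among the compounds with values here, these are the only two numbers so far, and compound 2 stands level with compound 1 within the scatter.

The next structure is compound 3 `CSc1sc(C(=N)N)cc1S(=O)(=O)c1cccc(-c2c(C)cccc2NC(=O)NCCCCCC(=O)O)c1`, with (5-carboxypentyl)amino in place of (methylsulfonyl)methyl on a carbonyl carbon.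

Within the data shown here, only one measured step bears on this change: a 1.1-fold higher number from compound 1 to compound 2 (0.03 log units; within the scatter), with methylsulfonyl in place of 3-carboxypropyl on a saturated chain carbon bound to a carbonyl carbon. That exchange of chain ends left the number within the scatter. Among the measured compounds shown here, no measured step covers an amino group on the carbonyl carbon, so the evidence is thin and the range is kept wide.

No step beyond the scatter is expected in this assay, and the expected step is a 1.1-fold lower number from compound 2 to compound 3 (0.03 log units; within the scatter). For compound 3 the estimated value is 40000 nM, with an expected range from 16000 nM to 100000 nM.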

Compound 3, solubility: 39000 nM
Beside the measured number, compound 3's estimate is 1.0-fold (0.01 log units) above it; measured number inside the range.
By their numbers in this assay, from the lowest: compounds 3, 1 and 2 (each within the scatter of the next).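

In this assay, (5-carboxypentyl)amino in place of (methylsulfonyl)methyl on a carbonyl carbon gives a 1.1-fold lower number from compound 2 to compound 3 (0.04 log units; within the scatter), so a larger entering group with hydrogen-bond donors, which the leaving group lacks, still produces no step beyond the scatter. The closer comparison, (5-carboxypentyl)amino in place of 4-carboxybutyl on a carbonyl carbon, gives a 1.0-fold lower number from compound 1 to compound 3 (0.01 log units; within the scatter), which extends the flat picture from changes further along the chain to an amino group bound directly to the carbonyl carbon. No supporting measurement is available to account for this flat result.

The compounds shown leave open whether a side chain ending in an amine, or one carrying a ring, would give a step beyond the scatter in this assay. They also leave open whether a much shorter chain on the amino group, with or without the carboxylic acid, would stay within the scatter of compound 3.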